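This account rests on a few compounds, and the source may have more. Where it says the series, first, only, none or still open, it means among the compounds named here.

Of the compounds shown here, two have so far been tested in an assay on isolated protein for inhibition of thyroid hormone receptor beta (Homo sapiens), read by fluorescence polarization; a higher number here means a weaker inhibitor, a lower number a stronger inhibitor. Compound 1, `CN(Cc1cccc(F)c1)C(=O)CCCNC(=O)c1ccc(S(C)(=O)=O)c([N+](=O)[O-])c1`, carries a (3-fluorobenzyl)(methyl)amino group on an amide carbonyl. In this assay compound 1 reaches only the limit of the measurement, > 60000 nM. Compound 2, `CCCN(C(=O)CN(C)C(=O)c1ccc(S(C)(=O)=O)c([N+](=O)[O-])c1)c1ccccc1`, carries a phenyl(propyl)amino group on its terminal carbonyl. In this assay compound 2 likewise stops at the limit, > 60000 nM. Compound 2 therefore stands exactly where every value shown stands, namely at the limit of > 60000 nM in this assay, at which 2 of the 2 values shown sit, so the numbers do not separate it from compound 1, and neither compound shows measurable inhibition.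

Compound 3, `CN(Cc1cccc(F)c1)C(=O)CN(C)C(=O)c1ccc(S(C)(=O)=O)c([N+](=O)[O-])c1`, keeps the shared core of compound 2 and changes only the end group: (3-fluorobenzyl)(methyl)amino in place of phenyl(propyl)amino on a carbonyl carbon. For the measured compounds named here, the group that enters is the one already present in compound 1, which also gave only a limit. Going by the values given here, with both measured compounds sitting at the limit, no step between them can be read, and no change beyond the usual scatter is expected. The shift from compound 2 to compound 3 is expected to be a step that the limit leaves unreadable from compound 2 to compound 3. Compound 3 is estimated at 100000 nM, with a likely range from 30000 nM to 300000 nM, and most probably it will again be reported only as a limit.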

Compound 3, half-maximal inhibitory concentration: > 60000 nM
Compound 3: only a limit was reported (the forecaster's own chance of this, stated with the estimate: 85%); the middle value is on the limit's open side.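

For the compounds shown here, compound 3 gives only a limit in this assay, > 60000 nM, and compound 2 also gave only a limit, so no step from compound 2 to compound 3 can be read. Whether the compounds shown differ at all, and which end group might give measurable inhibition, stays open because all of them rest at one mark: the limit of > 60000 nM in this assay, at which 3 of the 3 values shown sit.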